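The source may report more compounds than this note shows. Statements on the series, on what has been measured and on what is new or still open speak of the compounds shown alone.

Three compounds share one core and differ only in the aromatic ring attached to the sulfonyl sulfur. In an assay on isolated protein for displacement of a labelled ligand from metabotropic glutamate receptor 5 (Homo sapiens), with a stated time of 60 min, tested at 1 uM (on this read-out higher numbers stand for more inhibition at the one concentration tested (going by the name of the read-out) and lower numbers for less inhibition), compound 1 `Cc1ccc2ncc(S(=O)(=O)c3cc(Cl)cc(Cl)c3)c(N3CCC(C)CC3)c2c1` gives 75%. Compound 2 `Cc1ccc2ncc(S(=O)(=O)c3ccc(C)c(C)c3)c(N3CCC(C)CC3)c2c1` gives 90% in this assay, and compound 3 `Cc1ccc2ncc(S(=O)(=O)c3ccc(F)c(Cl)c3)c(N3CCC(C)CC3)c2c1` gives 93%. Compound 3 thus holds the highest of the three numbers, though its gap to compound 2 lies within the scatter, while its gap to compound 1 lies beyond it. The steps read a number 15 percentage points higher from compound 1 to compound 2 (beyond the scatter), a number 18 percentage points higher from compound 1 to compound 3 (beyond the scatter) and a number 3 percentage points higher from compound 2 to compound 3 (within the scatter).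

Compound 4 `Cc1ccc(S(=O)(=O)c2cnc3ccc(C)cc3c2N2CCC(C)CC2)cc1` differs from compound 3 in one place: 4-methylphenyl in place of 3-chloro-4-fluorophenyl on a sulfonyl sulfur. Among the compounds with values here, two measured steps bear on this. Putting 3,4-dimethylphenyl in place of 3,5-dichlorophenyl raised the number modestly, and swapping 3,4-dimethylphenyl for 3-chloro-4-fluorophenyl changed it only within the scatter. A ring carrying a single methyl group, with no halogen, is therefore expected to land close to compounds 2 and 3, with at most a small drop in this assay, so compound 4 is estimated at 85%, between 68% and 95%. The expected step is a number 8 percentage points lower from compound 3 to compound 4 (within the scatter), likely within the scatter.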

Compound 4, a percentage reported as inhibition, at one concentration (the size of the read-out at that concentration, not a potency): 82%
Compound 4: middle estimate off by 3 percentage points, on the high side, and the stated range covers the measured number.
By their numbers in this assay, from the lowest: compounds 1, 4, 2 and 3 (each within the scatter of the next, the first and the last beyond it).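

In this assay, 4-methylphenyl on the sulfonyl sulfur is separated from 3-chloro-4-fluorophenyl, with a number 11 percentage points lower from compound 3 to compound 4 (beyond the scatter) as the step. Yet the step for hydrogen in place of methyl on an aromatic carbon is a number 8 percentage points lower from compound 2 to compound 4 (within the scatter), and the step for 4-methylphenyl in place of 3,5-dichlorophenyl is a number 7 percentage points higher from compound 1 to compound 4 (within the scatter), so compound 4 cannot be told apart from compound 2 or compound 1, even though those two are separated from each other. Nothing available here explains these differences.

From the compounds shown here alone, all four rings carry only methyl, chlorine or fluorine, so what a methoxy group, a nitrile or an amine on this ring would do remains open. With one concentration per compound, these percentages also leave the actual potencies open.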